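Aryl swap on the triazole nitrogen of compound 2

This account rests on a few compounds, and the source may have more. Where it says the series, first, only, none or still open, it means among the compounds named here.

Measured compounds in a functional assay on HepG2 cells (Homo sapiens) for inhibition, read by MTT assay, with a stated time of 72 h, tested at 50 uM; on this read-out higher numbers stand for more inhibition of growth at the one concentration tested and lower numbers for less inhibition of growth:
compound 1, `C=CCc1cc(O)c(O)c(CN2CCC(Cc3ccccc3)CC2)c1`, 84%
compound 2, `C=CCc1ccc(OCc2cn(-c3cccc(C#N)c3)nn2)c(O)c1`, 3.4%
compound 3, `C=CCc1ccc(OCc2cn(-c3cccc([N+](=O)[O-])c3)nn2)c(O)c1`, 30.2%

Compound 2 stands lowest of the three numbers measured in this assay. Its nearest neighbour is compound 3, where the step of a number 26.8 percentage points higher from compound 2 to compound 3 (beyond the scatter) lies beyond the scatter; the furthest is compound 1, which gives 84%, whereas compound 2 gives 3.4%, a gap that lies far beyond the scatter.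

The unmeasured compound 4 is `C=CCc1ccc(OCc2cn(-c3ccc(OC)cc3)nn2)c(O)c1`. It differs from compound 2 by 4-methoxyphenyl in place of 3-cyanophenyl on an aromatic nitrogen. Among the measured compounds shown here, the one measured step that touches the same aromatic nitrogen of a five-membered aromatic ring with 3 nitrogen is the step from compound 2 to compound 3, which exchanged only the substituent on the aryl ring and gave a number 26.8 percentage points higher from compound 2 to compound 3 (beyond the scatter). For the measured compounds named here, no measured pair shows a 4-methoxyphenyl at this place, so the direction of the present change has to be taken as open. Going by the values given here, because the only change recorded at this position, a number 26.8 percentage points higher from compound 2 to compound 3 (beyond the scatter), was modest, a modest movement at most is expected for compound 4, and the expected step of a number 8.6 percentage points higher from compound 2 to compound 4 (within the scatter) may not exceed the scatter. Compound 4 is therefore estimated at 12% in this assay, with a range from 0% to 35%.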

Compound 4, percent growth inhibition at one concentration: 49.9%
Estimate against measurement, compound 4: 37.9 percentage points below, outside the stated range (above it).
By their numbers in this assay, from the lowest: compound 2; then compound 3; then compound 4; then compound 1.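

In this assay, the aryl group on the aromatic nitrogen of the triazole turns out to be able to carry a large change: the swap of 3-cyanophenyl for 4-methoxyphenyl gives a number 46.5 percentage points higher from compound 2 to compound 4 (beyond the scatter), whereas the earlier exchange gave only the modest a number 26.8 percentage points higher from compound 2 to compound 3 (beyond the scatter). The two groups that trade places have the same counts of heavy atoms, hydrogen-bond donors and hydrogen-bond acceptors, so these counts do not separate compound 2 from compound 4. Nothing at hand accounts for the rise, which stands as a single observation for this swap.

The compounds shown leave open whether the rise goes with the methoxy group replacing the nitrile or with the changed place of the substituent on the aryl ring, as this step alters both at once. Also open, on these data alone, is how an amine or a carboxylic acid on that aryl ring, or a longer chain in place of the methoxy group, would read at this aromatic nitrogen.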